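Dichlorobenzyl swap on a thiophene carboxamide core

The compounds below may be only part of what the source reports. "The series", "measured", "known", "first", "only" and "open" are said of these compounds alone.

Measured so far:
Compound 1, `NC(=O)c1c(NC(=O)c2ccc(C(F)(F)F)cc2)sc2c1CCN(Cc1c(Cl)cccc1Cl)C2`: 10600 nM
Compound 2, `NC(=O)c1c(NC(=O)c2ccc(C(F)(F)F)cc2)sc2c1CCN(Cc1ccc(Cl)cc1Cl)C2`: 14900 nM
Compound 3, `NC(=O)c1c(NC(=O)c2ccccc2F)sc2c1CCN(Cc1c(Cl)cccc1Cl)C2`: 10300 nM

All three were tested in a functional assay on HL-60 cells (Homo sapiens) for antiproliferative activity, with a stated time of 24 h; a lower number here means a stronger inhibitor, a higher number a weaker inhibitor. Compound 1 gives 10600 nM in this assay, compound 2 gives 14900 nM and compound 3 gives 10300 nM; these three numbers sit within the scatter of one another, so none can be called stronger or weaker.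

Compound 2 differs from compound 1 by 2,4-dichlorophenyl in place of 2,6-dichlorophenyl on a saturated chain carbon bound to an amine nitrogen in a ring, and that change made a step of a 1.4-fold higher number from compound 1 to compound 2 (0.15 log units; within the scatter). Compound 3 differs from compound 1 by 2-fluorophenyl in place of 4-(trifluoromethyl)phenyl on a carbonyl carbon, a step of a 1.0-fold lower number from compound 1 to compound 3 (0.01 log units; within the scatter).

Compound 4, `NC(=O)c1c(NC(=O)c2ccccc2F)sc2c1CCN(Cc1ccc(Cl)cc1Cl)C2`, has not yet been measured. Among the measured compounds shown here, it differs from compound 3 by 2,4-dichlorophenyl in place of 2,6-dichlorophenyl on a saturated chain carbon bound to an amine nitrogen in a ring, which is the same change as the one from compound 1 to compound 2, made on a core that differs by 2-fluorophenyl in place of 4-(trifluoromethyl)phenyl on a carbonyl carbon. Because the earlier step was a 1.4-fold higher number from compound 1 to compound 2 (0.15 log units; within the scatter), a step of about a 1.4-fold higher number from compound 3 to compound 4 (0.13 log units; within the scatter) is expected here, though a single earlier instance is a thin basis. Compound 4 is therefore estimated at 14000 nM in this assay, with a likely range from 7000 nM to 28000 nM.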

Compound 4, half-maximal inhibitory concentration: 13100 nM
Estimate against measurement, compound 4: 1.1-fold (0.03 log units) above; low and high end bracket the measured number.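

In this assay, putting 2,4-dichlorophenyl in place of 2,6-dichlorophenyl on the core carrying the 2-fluorophenyl amide gives a 1.3-fold higher number from compound 3 to compound 4 (0.10 log units; within the scatter), and this step agrees with the one seen on the first core: the same change on two cores in this assay, a 1.4-fold higher number (0.15 log units; within the scatter) from compound 1 to compound 2 and a 1.3-fold higher number (0.10 log units; within the scatter) from compound 3 to compound 4, 1.1-fold (0.04 log units) apart, within the scatter of two such steps. The other change, 2-fluorophenyl in place of 4-(trifluoromethyl)phenyl on a carbonyl carbon, gives a 1.1-fold lower number from compound 2 to compound 4 (0.06 log units; within the scatter), and it too agrees with its earlier instance: the same change on two cores in this assay, a 1.0-fold lower number (0.01 log units; within the scatter) from compound 1 to compound 3 and a 1.1-fold lower number (0.06 log units; within the scatter) from compound 2 to compound 4, 1.1-fold (0.04 log units) apart, within the scatter of two such steps. Among the compounds shown here, all of these steps lie within the scatter, so the agreement shows only that neither change made a readable difference on either core, not that a real effect carries over from one core to another.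

Going by these compounds, it remains open whether a different kind of group, such as an amine or a carboxylic acid in place of the chlorines, or a longer chain in place of the saturated chain carbon, would move the number beyond the scatter. On these data alone, whether these flat steps would hold on cores other than these two is also open.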